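Arylhydrazone series: ortho nitro in place of ortho chloro

The source may report more compounds than this note shows. Statements on the series, on what has been measured and on what is new or still open speak of the compounds shown alone.

Compound 1 `CC1CC/C(=N\Nc2ccccc2Cl)c2ncc(C(=O)O)c(=O)n21`: > 1000 umol/kg (a limit)
Compound 2 `CC1CC/C(=N\Nc2cccc(I)c2)c2ncc(C(=O)O)c(=O)n21`: 1000 umol/kg
Compound 3 `Cc1cccc(N/N=C2\CCC(C)n3c2ncc(C(=O)O)c3=O)c1`: 72.5 umol/kg

In a functional assay on the whole organism for inhibition, with Rattus norvegicus as the target (on this read-out lower numbers stand for an effect already at smaller amounts and higher numbers for an effect only at larger amounts of compound), compound 1 reports only a limit, > 1000 umol/kg, not a number; this is the limit of > 1000 umol/kg in this assay, at which 1 of the 3 values shown sits. Compound 4 `CC1CC/C(=N\Nc2ccccc2[N+](=O)[O-])c2ncc(C(=O)O)c(=O)n21` differs from compound 1 by nitro in place of chloro on an aromatic carbon. Two measured steps leave compound 1: a number no higher from compound 1 to compound 2 (the limit leaves the size open), and an at least 13-fold lower number from compound 1 to compound 3 (1.13 log units; beyond the scatter). Within the data shown here, both move the substituent to the 3-position of the phenyl; no measured step keeps the ortho position and exchanges one group for another, and no compound carries a nitro group. The step to compound 4 is therefore unsupported, and with compound 2 at 1000 umol/kg the weak end of the series is where most of the data sit. Compound 4 is expected near 1000 umol/kg, between 300 umol/kg and 3000 umol/kg, which would be a number no higher from compound 1 to compound 4 (the limit leaves the size open), quite possibly again only a limit.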

Compound 4, dose for 50% inhibition: > 1000 umol/kg
Compound 4 was reported as a limit (the forecaster's own chance of this, stated with the estimate: 55%); the middle value lies on the limit itself.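

Compound 1 stands as a limit, > 1000 umol/kg. Compound 4 is also a limit, > 1000 umol/kg, so the step between these two compounds cannot be read. As far as these compounds go, how nitro compares with chloro in this assay remains open.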